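The source may report more compounds than this note shows. Statements on the series, on what has been measured and on what is new or still open speak of the compounds shown alone.

Measured compounds in an assay for inhibition of Nitric oxide synthase, inducible (Homo sapiens), read by scintillation counting, with a stated time of 30 min, tested at 1 mM; on this read-out higher numbers stand for more inhibition at the one concentration tested (going by the name of the read-out) and lower numbers for less inhibition:

compound 1, `CNC(=S)NCCC(O)c1ccccc1N`: 20.7%
compound 2, `CCNC(=S)NCCC(O)c1ccccc1N`: 19.4%
compound 3, `CNC(=S)NCCC(O)c1cc(Cl)ccc1N`: 22.1%

Compound 3 carries the highest of the three numbers in this assay, but neither gap separates it from the others: compound 1 sits a number 1.4 percentage points higher from compound 1 to compound 3 (within the scatter) away, and compound 2 is further off only by a margin that stays within the scatter too. The three numbers are, in effect, one level of inhibition at the single concentration tested.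

Compound 4, `CCNC(=S)NCCC(O)c1cc(Cl)ccc1N`, is the chloro-bearing analogue of compound 2 and is yet to be measured in this assay. Against compound 3 the change is methyl in place of hydrogen on a saturated chain carbon bound to an amide-type nitrogen. The same change has been seen once before on this series, on the core without the chloro substituent: a number 1.3 percentage points lower from compound 1 to compound 2 (within the scatter), a step that stays within the scatter. The chloro substituent itself, a number 1.4 percentage points higher from compound 1 to compound 3 (within the scatter), likewise produced no step beyond the scatter. For the measured compounds named here, nothing among the measured compounds suggests that the two changes together behave differently from each singly.

The expected step in this assay is therefore a number 1.1 percentage points lower from compound 3 to compound 4 (within the scatter), a change within the scatter. For compound 4 the estimated inhibition is 21%, expected to fall between 11% and 31%.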

Compound 4, a percentage reported as inhibition, at one concentration (the size of the read-out at that concentration, not a potency): 60.4%
Estimate against measurement, compound 4: 39.4 percentage points below, and the stated range ends below it.
By their numbers in this assay, from the lowest: compounds 2, 1 and 3 (each within the scatter of the next); then compound 4.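

In this assay, methyl in place of hydrogen on a saturated chain carbon bound to an amide-type nitrogen gives a number 38.3 percentage points higher from compound 3 to compound 4 (beyond the scatter), so the outcome of this change depends on the core that carries it: the same change on two cores in this assay, a number 1.3 percentage points lower (within the scatter) from compound 1 to compound 2 and a number 38.3 percentage points higher (beyond the scatter) from compound 3 to compound 4, 39.6 percentage points apart, beyond the scatter of two such steps

Read from the other side, chloro in place of hydrogen on an aromatic carbon gives a number 41 percentage points higher from compound 2 to compound 4 (beyond the scatter), so the chloro substituent also counts only on the core that already holds the ethylamino group: the same change on two cores in this assay, a number 1.4 percentage points higher (within the scatter) from compound 1 to compound 3 and a number 41 percentage points higher (beyond the scatter) from compound 2 to compound 4, 39.6 percentage points apart, beyond the scatter of two such steps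

Each change alone stayed within the scatter on the core of compound 1, with a number 1.3 percentage points lower from compound 1 to compound 2 (within the scatter) and a number 1.4 percentage points higher from compound 1 to compound 3 (within the scatter), so the two changes do not add up as independent steps here, and the high number appears only where both are present.

The compounds shown leave open whether a propyl chain in place of the ethyl group on the chloro-bearing core carries the rise further, and whether bromo in place of chloro pairs with the ethylamino group in the same way. With a read-out taken at one concentration, they also leave open how far the step seen for compound 4 would hold up as a difference in potency.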